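The source may hold more compounds than are shown below. What is called first, only, known or untested is meant among the compounds shown, and "the series" means these compounds.

In a physicochemical assay for lipophilicity, at pH 7.4 (a lower number here means a more polar compound, a higher number a more lipophilic compound), the three measured compounds gave the following numbers:

Compound 1 `Cc1nn(C)c(C)c1-c1ccc(-c2nnc(N(C)Cc3ccc4nccn4c3)o2)cc1`: 3.1
Compound 2 `Cc1nn(C)c(C)c1-c1ccc(-c2nnc(N(C)Cc3ccc4nccn4c3)o2)c(F)c1`: 3.2
Compound 3 `Cc1cc(-c2c(C)nn(C)c2C)ccc1-c1nnc(N(C)Cc2ccc3nccn3c2)o1`: 3.7

Compound 3 stands highest of the three: the steps of a number 0.60 log units higher from compound 1 to compound 3 (beyond the scatter) and a number 0.50 log units higher from compound 2 to compound 3 (beyond the scatter) both lie beyond the scatter, whereas the step of a number 0.10 log units higher from compound 1 to compound 2 (within the scatter) does not. Compound 4 `Cc1cc(-c2c(C)n[nH]c2C)ccc1-c1nnc(N(C)Cc2ccc3nccn3c2)o1` differs from compound 3 in one place: hydrogen in place of methyl on an aromatic nitrogen. Within the data shown here, none of the measured steps touches the ring nitrogen, so there is no direct precedent for this change. The nearest guide is the methyl that entered on an aromatic carbon, which gave the steps of a number 0.60 log units higher from compound 1 to compound 3 (beyond the scatter) and a number 0.50 log units higher from compound 2 to compound 3 (beyond the scatter), both modest and upward. Taking a methyl away is therefore expected to move the number in this assay the other way, by a step of roughly that size, though the new position is a nitrogen rather than a carbon. Compound 4 is accordingly expected to give 3.1, with a range from 2.6 to 3.6. This amounts to an estimated step of a number 0.60 log units lower from compound 3 to compound 4 (beyond the scatter).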

Compound 4, distribution coefficient: 3.8
Estimate against measurement, compound 4: 0.70 log units below, outside the stated range (above it).
By their numbers in this assay, from the lowest: compounds 1 and 2 (each within the scatter of the next); then compounds 3 and 4 (each within the scatter of the next).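

In this assay the change from 1,3,5-trimethyl-1H-pyrazol-4-yl to 3,5-dimethyl-1H-pyrazol-4-yl gives a number 0.10 log units higher from compound 3 to compound 4 (within the scatter) and so cannot be told apart from no change at all. A methyl entering on an aromatic carbon gave a number 0.60 log units higher from compound 1 to compound 3 (beyond the scatter) in the same assay, so in these compounds a methyl at one place says little about a methyl at another: the step on the carbon does not carry over, in reverse, to the aromatic nitrogen. Nothing measured here explains why the two positions differ.

The compounds shown leave open whether this nitrogen would stay as unresponsive with a larger group on it, such as an ethyl, a longer chain or a chain ending in an amine. They also leave open whether the same swap would read the same way on the core of compound 1 or compound 2.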